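Aryl group change on the ring amine of compound 3

This account rests on a few compounds, and the source may have more. Where it says the series, first, only, none or still open, it means among the compounds named here.

Among the measured compounds shown here, compound 3 `Cc1nc(-c2ccccc2)c(C(=O)N2CCN(c3ccccc3Cl)CC2)o1` is the only member of the series with a number in a functional assay on HL-60 cells (Homo sapiens) for inhibition, read by MTT assay, with a stated time of 72 h; on this read-out lower numbers stand for stronger inhibition and higher numbers for weaker inhibition: in this assay compound 3 gives 124 nM. For the measured compounds named here, compound 1 `O=C(c1oc(C(F)(F)F)nc1-c1ccccc1F)N1CCN(c2cccc(Cl)c2)CC1` is reported in this assay as "not active" (no number reported), and compound 2 `COc1ccc(-c2nc(C)oc2C(=O)N2CCN(c3cccc(Cl)c3)CC2)cc1` is likewise reported in this assay as "not active" (no number reported); neither carries a number, so no step between measured compounds can be drawn, and how compound 3 compares with compound 1 and compound 2 rests only on the fact that compound 3 has a value and they have none.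

Compound 4 `CC(=O)Nc1cccc(N2CCN(C(=O)c3oc(C)nc3-c3ccccc3)CC2)c1` differs from compound 3 in one place: 3-acetamidophenyl in place of 2-chlorophenyl on an amine nitrogen in a ring. Compound 1 and compound 2 both carry a chlorophenyl on the ring amine and are not active, but each also differs from compound 3 elsewhere, so the data do not isolate this position.

The expected step in this assay is a 3.6-fold higher number from compound 3 to compound 4 (0.56 log units; beyond the scatter), a loss beyond the usual scatter, with a fair chance that no number is obtained. Compound 4 is estimated at 450 nM, with a range from 100 nM to 3000 nM.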

Compound 4, half-maximal inhibitory concentration: 329 nM
Compound 4: the middle estimate sits 1.4-fold (0.14 log units) above what was measured; the measured number falls inside the stated range.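

Among the compounds shown here, the aryl group on the ring amine is isolated here for the first time: in this assay, 3-acetamidophenyl in place of 2-chlorophenyl gives a 2.7-fold higher number from compound 3 to compound 4 (0.42 log units; beyond the scatter), a modest loss that still leaves a measurable number. The position therefore accepts a larger aryl group carrying a hydrogen-bond donor and acceptor, although the substituent and its place on the phenyl ring change together, so the step cannot be assigned to either alone. No measurement shown bears on the reason for this step.

Steps from compound 1 and compound 2 cannot be read, so the part played by the aryl group in those two entries stays open. Also open, from the compounds shown here alone, is how an unsubstituted phenyl, or an amine or carboxylic acid in place of the acetamido group, would compare with compound 4.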